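A few compounds are considered here, and "the series" means these few. Any claim that something is new, unique, unknown or untested is made for them only; others in the source may bear on it.

Working notes on the ethers of the shared core, tested in a functional assay on LNCaP cells (Homo sapiens) for antiproliferative activity, read by WST assay, with a stated time of 3 days; a higher number here means a weaker inhibitor, a lower number a stronger inhibitor. Compound 1 (`CCCCCCOc1c(-c2cc(OC)c(OC)c(OC)c2)oc2ccccc2c1=O`) gives 19600 nM, compound 2 (`COc1cc(-c2oc3ccccc3c(=O)c2OC(C)C)cc(OC)c1OC`) gives 8800 nM, and compound 3 (`CCN(CC)CCCCOc1c(-c2cc(OC)c(OC)c(OC)c2)oc2ccccc2c1=O`) gives 13500 nM. Compound 3 stands within the scatter of both others, with a 1.5-fold lower number from compound 1 to compound 3 (0.16 log units; within the scatter) and a 1.5-fold higher number from compound 2 to compound 3 (0.19 log units; within the scatter). Only a 2.2-fold lower number from compound 1 to compound 2 (0.35 log units; beyond the scatter) exceeds the scatter, and it is modest.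

Compound 4 (`CCCN(CCC)CCCCOc1c(-c2cc(OC)c(OC)c(OC)c2)oc2ccccc2c1=O`) alters the amine of compound 3: dipropylamino in place of diethylamino on a saturated chain carbon, four bonds along the chain from an oxygen on an aromatic ring. Going by the values given here, no measured step makes this same exchange. The nearest evidence is the step that placed diethylamino at this chain position, a 1.5-fold lower number from compound 1 to compound 3 (0.16 log units; within the scatter), which stayed within the scatter. Replacing the whole group on the oxygen gave a 1.5-fold higher number from compound 2 to compound 3 (0.19 log units; within the scatter), also within the scatter. Among the compounds with values here, with only three compounds, this is thin support, but nothing measured points to a large effect or a particular direction. The expected result is a 1.0-fold lower number from compound 3 to compound 4 (0.02 log units; within the scatter), with no change beyond the scatter. Compound 4 is estimated at 13000 nM, with an expected range of 6000 nM to 26000 nM.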

Compound 4, half-maximal inhibitory concentration: 16800 nM
Estimate against measurement, compound 4: 1.3-fold (0.11 log units) below; measured number inside the range.
By their numbers in this assay, from the lowest: compounds 2, 3, 4 and 1 (each within the scatter of the next, the first and the last beyond it).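

Going by these compounds alone, the first exchange at the amine itself, dipropylamino in place of diethylamino, gives a 1.2-fold higher number from compound 3 to compound 4 (0.09 log units; within the scatter) in this assay, so this change on the chain does not separate the two amines. Compound 4 also stays within the scatter of both simpler ethers, with a 1.9-fold higher number from compound 2 to compound 4 (0.28 log units; within the scatter) and a 1.2-fold lower number from compound 1 to compound 4 (0.07 log units; within the scatter), even though compound 1 and compound 2 lie beyond the scatter of each other. Nothing available explains these small differences.

The compounds shown leave open whether a ring amine such as piperidine or morpholine in place of dipropylamino would move the number beyond the scatter. Also open, on these data alone, is whether a shorter or longer chain carrying the diethylamino group, or a carboxylic acid at the chain end, would do so.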